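This account rests on a few compounds, and the source may have more. Where it says the series, first, only, none or still open, it means among the compounds named here.

Compound 1 `CCCCCn1ccc2cc(/C(C)=C/C(=O)Nc3ccccc3OCCCC(=O)O)ccc21` gives the lowest number of the three measured compounds in an assay on Prostate gland for inhibition of steroid 5-alpha-reductase (Rattus norvegicus) (on this read-out higher numbers stand for weaker inhibition and lower numbers for stronger inhibition), at 23 nM. Compound 2 `CCCCCCn1ccc2cc(/C(C)=C/C(=O)Nc3ccccc3OCCCC(=O)O)ccc21` gives 77 nM, and compound 3 `C/C(=C\C(=O)Nc1ccccc1OCCCC(=O)O)c1ccc2c(ccn2Cc2ccccc2C)c1` gives 69 nM. Both changes made from compound 1 moved the reading upward: a 3.3-fold higher number from compound 1 to compound 2 (0.52 log units; beyond the scatter) and a 3.0-fold higher number from compound 1 to compound 3 (0.48 log units; beyond the scatter). Between the two weaker compounds there is little to separate, as a 1.1-fold lower number from compound 2 to compound 3 (0.05 log units; within the scatter).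

Compound 4 `C/C(=C\C(=O)Nc1ccccc1OCCCC(=O)O)c1ccc2c(ccn2Cc2ccc(C(F)(F)F)cc2)c1` has not yet been measured in this assay. It departs from compound 1 by 4-(trifluoromethyl)phenyl in place of butyl on a saturated chain carbon bound to an aromatic nitrogen. The step that bears most directly on this change is the one in which 2-methylphenyl replaced butyl on the saturated chain carbon bound to the aromatic nitrogen, which was modest and beyond the scatter: a 3.0-fold higher number from compound 1 to compound 3 (0.48 log units; beyond the scatter). An aromatic ring entering at the same place in compound 4 is therefore expected to give a similar modest rise, so that compound 4 is expected to show about 65 nM, within a range of 25 nM to 170 nM, which would amount to a 2.8-fold higher number from compound 1 to compound 4 (0.45 log units; beyond the scatter).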

Compound 4, half-maximal inhibitory concentration: 300 nM
For compound 4 the middle estimate is 4.6-fold (0.66 log units) below the measured one; measured number above the stated range.
By their numbers in this assay, from the lowest: compound 1; then compounds 3 and 2 (each within the scatter of the next); then compound 4.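

At the saturated chain carbon bound to an aromatic nitrogen, an aromatic ring does not have one fixed effect in this assay: 4-(trifluoromethyl)phenyl in place of butyl gives a 13-fold higher number from compound 1 to compound 4 (1.12 log units; beyond the scatter), a much larger rise than 2-methylphenyl gave. The two rings also differ from each other, with a 4.3-fold higher number from compound 3 to compound 4 (0.64 log units; beyond the scatter), and the new group also falls short of the longer chain, with a 3.9-fold higher number from compound 2 to compound 4 (0.59 log units; beyond the scatter), so what the ring carries or where it carries it matters here. Nothing available explains this rise.

The compounds shown leave open how much of the step belongs to the ring and how much to the trifluoromethyl group. As far as these compounds go, an unsubstituted phenyl group at this place, or a methyl or chlorine on the ring in its stead, would separate the two, while a chain shorter than butyl remains unexplored.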